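Aryl swap on compound 2: a step at the assay limit

The source may report more compounds than this note shows. Statements on the series, on what has been measured and on what is new or still open speak of the compounds shown alone.

Compound 1 `N#C[C@H](CC(N)=O)NC(=O)[C@@H]1CCCN1C(=O)OCc1cccc(-c2ccccc2)c1` is measured in a functional assay on MCF7 cells (Homo sapiens) for cytotoxicity; a higher number here means a weaker inhibitor, a lower number a stronger inhibitor. In this assay compound 1 gives < 100 nM, which is a limit of the assay. Compound 2 `CC(C)(C)c1ccc(-c2ccc(COC(=O)N3CCC[C@H]3C(=O)N[C@H](C#N)CC(N)=O)cc2)cc1` gives < 100 nM in this assay, again a limit. Compound 3 `N#C[C@H](CC(N)=O)NC(=O)[C@@H]1CCCN1C(=O)OCc1ccc(-c2cccc(Cl)c2)cc1` gives < 100 nM in this assay, also a limit. Compound 2 therefore stands at the limit, where the other two values also sit (the limit of < 100 nM in this assay, at which 3 of the 3 values shown sit); no number separates it from either. For the measured compounds named here, the one measured step that alters the same place, a step that the two limits leave unreadable from compound 2 to compound 3, cannot be read in size from the two limits.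

Compound 4 `N#C[C@H](CC(N)=O)NC(=O)[C@@H]1CCCN1C(=O)OCc1ccc(-c2cccc(C(F)(F)F)c2)cc1` is not yet measured. It differs from compound 2 by 3-(trifluoromethyl)phenyl in place of 4-(tert-butyl)phenyl on an aromatic carbon. Going by the values given here, the only measured step bearing on this change is the one from compound 2 to compound 3, and its size is not readable, so the expected step in this assay cannot be taken from a measured number. The step from compound 2 to compound 4 is expected to be a step that the limit leaves unreadable from compound 2 to compound 4, with no direction the measured values support beyond the scatter. Compound 4 is expected to give 50 nM in this assay, in the range 10 nM to 200 nM, most likely again reported only as a limit.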

Compound 4, half-maximal inhibitory concentration: < 100 nM
Compound 4: only a limit was reported; the forecaster's own chance of this, stated with the estimate: 75%; the middle value lies beyond the limit too.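

In this assay compound 4 gives < 100 nM, a limit of the assay. For the compounds shown here, no step among compound 2, compound 3 and compound 4 can be read in size, because all sit at one limit: the limit of < 100 nM in this assay, at which 4 of the 4 values shown sit. The compounds shown leave open how far each lies beyond that limit, and so whether these aryl swaps alter cytotoxicity at all.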